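Group change on the amide nitrogen, compound 2 to compound 3

The source may report more compounds than this note shows. Statements on the series, on what has been measured and on what is new or still open speak of the compounds shown alone.

In an ADME assay on MT4 cells (Homo sapiens) for cytotoxicity, read by MTT assay (a higher number here means that more compound is tolerated, a lower number that less compound is tolerated), compound 2 (`Cc1cc(C)cc(S(=O)(=O)c2c(C(=O)Nc3ccc(CO)cc3)[nH]c3ccc(Cl)cc23)c1`) gives 39600 nM and compound 1 (`Cc1cc(C)cc(S(=O)(=O)c2c(C(=O)NCc3ccccc3N)[nH]c3ccc(Cl)cc23)c1`) gives 46200 nM, so the two stand within the scatter of each other. Compound 3 (`Cc1cc(C)cc(S(=O)(=O)c2c(C(=O)NCc3ccc(CO)cc3)[nH]c3ccc(Cl)cc23)c1`) has 4-(hydroxymethyl)benzyl in place of 4-(hydroxymethyl)phenyl on an amide-type nitrogen. Among the measured compounds shown here, the only measured step, a 1.2-fold lower number from compound 1 to compound 2 (0.07 log units; within the scatter), changes the group at that same nitrogen and stays within the scatter. One step is thin evidence, but no change beyond the scatter is expected in this assay. The estimated step is a 1.1-fold higher number from compound 2 to compound 3 (0.03 log units; within the scatter). Compound 3 is expected at 42000 nM, with an estimated range of 20000 nM to 85000 nM.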

Compound 3, half-maximal cytotoxic concentration: 31100 nM
Beside the measured number, compound 3's estimate is 1.4-fold (0.13 log units) above it, and the stated range covers the measured number.
By their numbers in this assay, from the lowest: compounds 3, 2 and 1 (each within the scatter of the next).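

In this assay, 4-(hydroxymethyl)benzyl in place of 4-(hydroxymethyl)phenyl on the amide-type nitrogen gives a 1.3-fold lower number from compound 2 to compound 3 (0.10 log units; within the scatter), so this group change at the nitrogen also leaves the read-out within the scatter. At the saturated chain carbon bound to that nitrogen, 4-(hydroxymethyl)phenyl in place of 2-aminophenyl gives a 1.5-fold lower number from compound 1 to compound 3 (0.17 log units; within the scatter), which extends the same result to a change of ring substituent. No measurement offers a reason for either step.

Still open, from the compounds shown here alone, is whether a carboxylic acid on the ring or a longer chain on the amide-type nitrogen would move the number beyond the scatter. The compounds shown give no group with a step beyond it.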